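Solubility notes on the imidazopyridine amine series, compound 3

The source may report more compounds than this note shows. Statements on the series, on what has been measured and on what is new or still open speak of the compounds shown alone.

Measured so far:
- compound 1 `FC(F)(F)c1cccc(-c2nc3cnc(Nc4cnccn4)cc3[nH]2)c1`: < 5000 nM
- compound 2 `FC(F)(F)c1ccc(Nc2cc3[nH]c(-c4cccc(C(F)(F)F)c4)nc3cn2)nc1`: < 5000 nM

In a physicochemical assay for solubility, using the shake flask method, in phosphate buffer, measured as kinetic solubility, with a stated time of 20 h, at pH 6.5 (a higher number here means a more soluble compound, a lower number a less soluble compound), compound 1 gives only a limit, < 5000 nM. Compound 2 likewise gives only a limit in this assay, < 5000 nM. Within the data shown here, the one measured step, a step that the two limits leave unreadable from compound 1 to compound 2, is therefore of unreadable size; all that is known is the limit of < 5000 nM in this assay, at which 2 of the 2 values shown sit. Compound 2 thus stands at the limit of this assay, with no number of its own.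

Compound 3 `FC(F)(F)c1ccc(Nc2cc3[nH]c([C@H]4CC[C@H](C(F)(F)F)CC4)nc3cn2)nc1` differs from compound 2 in one place: 4-(trifluoromethyl)cyclohexyl in place of 3-(trifluoromethyl)phenyl on an aromatic carbon. Among the measured compounds shown here, no measured step touches this kind of change, and the only step available, from pyrazin-2-yl to 5-(trifluoromethyl)pyridin-2-yl, cannot be read. The expectation for a step that the limit leaves unreadable from compound 2 to compound 3 therefore rests on nothing more than both measured values sitting at the same limit, so no step beyond the scatter is expected in either direction. Compound 3 is estimated at 2500 nM in this assay, within the range 500 nM to 10000 nM, most likely again reported as a limit.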

Compound 3, solubility: < 5000 nM
Compound 3 ended at the assay's limit; the forecaster's own chance of this, stated with the estimate: 70%; the middle value is on the limit's open side.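

Compound 3 returns only a limit in this assay, so the step from compound 2 to compound 3, like the earlier one from compound 1 to compound 2, cannot be read. The compounds shown leave open how soluble each one actually is and whether either change shifts the read-out, as all share one limit: the limit of < 5000 nM in this assay, at which 3 of the 3 values shown sit.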